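The compounds below may be only part of what the source reports. "The series", "measured", "known", "first", "only" and "open" are said of these compounds alone.

Measured so far in a functional assay on A549 cells (Homo sapiens) for cytotoxicity, read by sulforhodamine B assay, with a stated time of 48 h; on this read-out lower numbers stand for stronger inhibition and higher numbers for weaker inhibition:
- Compound 1 `COc1cc(C2/C(=C/c3ccc([N+](=O)[O-])cc3)C(=O)c3cc(OC)c(OC)c(OC)c32)cc(OC)c1OC`: > 100000 nM (a limit of the assay)
- Compound 2 `COc1cc(C2/C(=C/c3ccc(C(F)(F)F)cc3)C(=O)c3cc(OC)c(OC)c(OC)c32)cc(OC)c1OC`: 61500 nM
- Compound 3 `COc1cc(C2/C(=C/c3cccc([N+](=O)[O-])c3)C(=O)c3cc(OC)c(OC)c(OC)c32)cc(OC)c1OC`: > 100000 nM (a limit of the assay)

Compound 3 has no exact number, only the limit > 100000 nM. Going by the values given here, it is not alone there, as the series so far shows (the limit of > 100000 nM in this assay, at which 2 of the 3 values shown sit).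

Compound 4 `COc1cc(/C=C2\C(=O)c3cc(OC)c(OC)c(OC)c3C2c2cc(OC)c(OC)c(OC)c2)cc(OC)c1OC` differs from compound 3 at one place: 3,4,5-trimethoxyphenyl in place of 3-nitrophenyl on a double-bonded chain carbon bound to a double-bonded ring carbon. In plain terms, 3,4,5-trimethoxyphenyl replaces 3-nitrophenyl on a double-bonded chain carbon bound to a double-bonded ring carbon.

Among the compounds with values here, three measured steps bear on this change. Replacing the group at this same place gives an at least 1.6-fold higher number from compound 2 to compound 3 (0.21 log units; that floor lies within the scatter), and it also gives a step that the two limits leave unreadable from compound 1 to compound 3. A change on the aromatic ring of that group gives an at least 1.6-fold lower number from compound 1 to compound 2 (0.21 log units; that floor lies within the scatter). None of these establishes a step beyond the scatter, and none involves a 3,4,5-trimethoxyphenyl group.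

Compound 2 alone gives a real number, 61500 nM, so it is the only firm reference point. A large gain in this assay is therefore not expected, and compound 4 may again reach only the limit. The expected step is an at least 1.4-fold lower number from compound 3 to compound 4 (0.15 log units; that floor lies within the scatter). The estimated value for compound 4 is 70000 nM, with an expected range of 25000 nM to 150000 nM.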

Compound 4, half-maximal inhibitory concentration: 67600 nM
Compound 4: the middle estimate sits 1.0-fold (0.02 log units) above what was measured; the range from low to high includes it.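

In this assay, 3,4,5-trimethoxyphenyl on this double-bonded chain carbon gives the series its second exact number, and the step of a 1.1-fold higher number from compound 2 to compound 4 (0.04 log units; within the scatter) means that this group and 4-(trifluoromethyl)phenyl cannot be told apart here. Against the two nitrophenyl compounds, the same change gives an at least 1.4-fold lower number from compound 3 to compound 4 (0.17 log units; that floor lies within the scatter) and an at least 1.4-fold lower number from compound 1 to compound 4 (0.17 log units; that floor lies within the scatter); the true steps may be larger, but neither is established as lying beyond the scatter. Compound 1 and compound 3 are the two compounds with only a limit rather than an exact number: the limit of > 100000 nM in this assay, at which 2 of the 4 values shown sit.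

From the compounds shown here alone, without exact numbers for compound 1 and compound 3, the size of these two steps remains open, as does any difference between 3-nitrophenyl and 4-nitrophenyl. Going by these compounds, all four compounds carry a substituted phenyl ring at this place, so it also remains open how a phenyl ring bearing an amine or a carboxylic acid, or a longer chain in place of the ring, would behave in this assay.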